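Hydroxy on the ethyl chain of compound 2

The source may hold more compounds than are shown below. What is called first, only, known or untested is meant among the compounds shown, and "the series" means these compounds.

In an ADME assay on MRC5 cells (Homo sapiens) for cytotoxicity, read by fluorescence, with a stated time of 24 h (a lower number here means a stronger inhibitor, a higher number a weaker inhibitor), compound 2 `CCC1S/C(=N\N=C\c2c(-c3ccc(Cl)cc3)[nH]c3ccccc23)NC1=O` gives 8800 nM and compound 1 `O=C1N/C(=N/N=C/c2c(-c3ccc(Br)cc3)[nH]c3ccccc23)SC1CCO` gives 15900 nM. For the measured compounds named here, these two numbers lie within the scatter of each other, so compound 2 stands level with the only other measured compound.

Compound 3 `O=C1N/C(=N/N=C/c2c(-c3ccc(Cl)cc3)[nH]c3ccccc23)SC1CCO` differs from compound 2 by hydroxy in place of hydrogen on a saturated chain carbon, two bonds along the chain from a saturated ring carbon, which turns ethyl into 2-hydroxyethyl: hydroxy in place of hydrogen on a saturated chain carbon, two bonds along the chain from a saturated ring carbon.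

Going by the values given here, no measured pair shows this change alone. Among the compounds with values here, the only guide is compound 1, which also carries 2-hydroxyethyl and gives 15900 nM. The expected change is a 1.5-fold higher number from compound 2 to compound 3 (0.17 log units; within the scatter), a small move toward a higher number that stays within the scatter. For compound 3 the estimated value is 13000 nM, with an expected range of 6500 nM to 26000 nM.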

Compound 3, half-maximal inhibitory concentration: 13200 nM
The estimate for compound 3 lay 1.0-fold (0.01 log units) below the measured number; measured number inside the range.
By their numbers in this assay, from the lowest: compounds 2, 3 and 1 (each within the scatter of the next).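

The series now holds its first single-change pairs in this assay. Ethyl to 2-hydroxyethyl gives a 1.5-fold higher number from compound 2 to compound 3 (0.18 log units; within the scatter), so hydroxy in place of hydrogen on this saturated chain carbon is tolerated without a step beyond the scatter. Chloro in place of bromo on the aromatic carbon gives a 1.2-fold lower number from compound 1 to compound 3 (0.08 log units; within the scatter), so this halogen swap also stays within the scatter, and no information on cause bears on either step.

Open, as far as these compounds go, is whether an amine or a carboxylic acid in place of the hydroxy, or a longer chain such as 3-hydroxypropyl, would give a step beyond the scatter. Also open, from the compounds shown here alone, is whether fluoro or methoxy in place of chloro on the aromatic carbon would do so.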